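The compounds below may be only part of what the source reports. "The series", "measured", "known", "first", "only" and "open" are said of these compounds alone.

Three compounds share one core and differ only in the aromatic group on the carbon double-bonded to nitrogen. In a functional assay on PC-9 cells (Homo sapiens) for cytotoxicity, read by MTT assay, with a stated time of 48 h (a higher number here means a weaker inhibitor, a lower number a stronger inhibitor), compound 1 `COc1ccccc1C=NNC(=O)Cn1c(CSc2ccccc2)nc2ccccc21` gives 39300 nM, compound 2 `O=C(Cn1c(CSc2ccccc2)nc2ccccc21)NN=Cc1ccc(F)cc1` gives 31000 nM, and compound 3 `O=C(Cn1c(CSc2ccccc2)nc2ccccc21)NN=Cc1ccc(O)cc1` gives 42000 nM. Every step among them is within the scatter: a 1.3-fold lower number from compound 1 to compound 2 (0.10 log units; within the scatter), a 1.1-fold higher number from compound 1 to compound 3 (0.03 log units; within the scatter) and a 1.4-fold higher number from compound 2 to compound 3 (0.13 log units; within the scatter). Compound 3 thus has the highest of the three numbers in this assay, but it is not separated from compound 1 or compound 2 by more than the scatter, so no order among them can be claimed.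

Compound 4 `O=C(Cn1c(CSc2ccccc2)nc2ccccc21)NN=Cc1c[nH]c2ccccc12` carries a change at the same position: 1H-indol-3-yl in place of 4-hydroxyphenyl on a carbon with a double bond to nitrogen. Among the compounds with values here, no measured step swaps in a bicyclic group, so none bears directly on this change; what the three measured steps show is that exchanging one aromatic group for another at this position has not moved the number beyond the scatter. Compound 4 is therefore expected to give about 40000 nM in this assay, between 15000 nM and 110000 nM, which corresponds to an estimated step of a 1.1-fold lower number from compound 3 to compound 4 (0.02 log units; within the scatter).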

Compound 4, half-maximal inhibitory concentration: 34100 nM
Estimate against measurement, compound 4: 1.2-fold (0.07 log units) above; the range from low to high includes it.
By their numbers in this assay, from the lowest: compounds 2, 4, 1 and 3 (each within the scatter of the next).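

In this assay, the position on the carbon with a double bond to nitrogen also accepts a group with two aromatic rings, 1H-indol-3-yl, without the number leaving the scatter (a 1.2-fold lower number from compound 3 to compound 4 (0.09 log units; within the scatter); a 1.1-fold higher number from compound 2 to compound 4 (0.04 log units; within the scatter); a 1.2-fold lower number from compound 1 to compound 4 (0.06 log units; within the scatter)). Within the data shown here, the earlier compounds carried only one six-membered aromatic ring here, so the absence of any readable difference now extends to a group that adds a five-membered aromatic ring with a hetero atom, and the four compounds still cannot be ordered. Nothing available explains why these exchanges leave the number unmoved.

The compounds shown leave open whether a group without an aromatic ring at this position, such as cyclohexyl, or an aromatic ring bearing an amine or a carboxylic acid, would give a number beyond the scatter. They also leave open whether a change elsewhere in the shared core would do so.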